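Amide aryl replacement on a shared thiophene-biaryl core

The source may report more compounds than this note shows. Statements on the series, on what has been measured and on what is new or still open speak of the compounds shown alone.

Measured compounds:
- Compound 1 `COC(=O)c1scc(-c2ccc(NC(=O)c3cc(I)ccc3F)cc2)c1OC`: "not determined" (no result reported) in a functional assay on HeLa cells (Homo sapiens) for antiproliferative activity, read by MTT assay, with a stated time of 24 h; on this read-out lower numbers stand for stronger inhibition and higher numbers for weaker inhibition
- Compound 2 `COC(=O)c1scc(-c2ccc(NC(=O)c3ccc(C#N)nc3)cc2)c1OC`: "not determined" (no result reported) in this assay
- Compound 3 `COC(=O)c1scc(-c2ccc(NC(=O)c3ccc4ccccc4c3)cc2)c1OC`: 18200 nM

Within the data shown here, compound 1 stands without a number in this assay; the same holds for compound 2, so the only value on record in the set is that of compound 3, and it is a weak one. Among the measured compounds shown here, no pair of measured compounds that differ in one place is available, so no step can be sized.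

Compound 4 `COC(=O)c1scc(-c2ccc(NC(=O)c3ccccn3)cc2)c1OC` differs from compound 1 by the change (pyridin-2-yl in place of 2-fluoro-5-iodophenyl on a carbonyl carbon). For the measured compounds named here, with no number for compound 1 and no measured step that resembles this change, nothing supports a direction for it in this assay; the working assumption is a shift no larger than the usual scatter, anchored on the one value in hand, that of compound 3.

Compound 4 is therefore expected to give about 20000 nM in this assay, with an estimated range from 5000 nM to 80000 nM.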

Compound 4, half-maximal inhibitory concentration: > 50000 nM
Compound 4: a limit, no number (the forecaster's own chance of this, stated with the estimate: 30%); middle value at least 2.5-fold (0.39 log units) away from the limit.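

Compound 4 gives a limit and not a number in this assay: the limit of > 50000 nM in this assay, at which 1 of the 4 values shown sits.

Even so, the pair of compound 3 and compound 4 differs in one place and provides the first readable step in the series: pyridin-2-yl in place of naphthalen-2-yl on a carbonyl carbon gives an at least 2.7-fold higher number from compound 3 to compound 4 (0.43 log units; beyond the scatter). The identity of the aryl group at this position therefore affects the read-out, and this change moves it towards weaker inhibition, with the full size of the step left unknown by the limit.

Steps involving compound 1 or compound 2 cannot be read, so the effect of 2-fluoro-5-iodophenyl at this position stays open. Also open, as far as these compounds go, is whether a plain phenyl, or a naphthalen-2-yl carrying an amine or a carboxylic acid, would give a lower number than compound 3.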